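The compounds below may be only part of what the source reports. "The series", "measured", "known", "first", "only" and "open" are said of these compounds alone.

Values in a functional assay on HeLa cells (Homo sapiens) for antiproliferative activity, read by MTT assay, with a stated time of 72 h; a higher number here means a weaker inhibitor, a lower number a stronger inhibitor
- compound 1 `C/C=C/C(=O)Nc1cccc(Oc2nc(Nc3ccc(OC)nc3)nc3c2CSCC3)c1` gives 16500 nM
- compound 2 `CC/C=C/C(=O)Nc1cccc(Oc2nc(Nc3ccc(OC)nc3)nc3c2CSCC3)c1` gives 31200 nM

Compound 2, at 31200 nM in this series, lies within the scatter of compound 1. Compound 3 `COc1ccc(Nc2nc3c(c(Oc4cccc(NC(=O)/C=C/C(C)C)c4)n2)CSCC3)cn1` differs from compound 2 by methyl in place of hydrogen on a saturated chain carbon bound to a double-bonded chain carbon and a saturated chain carbon and reads as ethyl to isopropyl. Among the compounds with values here, one measured step bears on this: a 1.9-fold higher number from compound 1 to compound 2 (0.28 log units; within the scatter) for methyl in place of hydrogen on a saturated chain carbon bound to a double-bonded chain carbon. On that single step, nothing beyond the scatter is expected in this assay and the estimated step is a 1.1-fold higher number from compound 2 to compound 3 (0.05 log units; within the scatter) with no firm direction. Compound 3 is estimated at 35000 nM with an expected range of 15000 nM to 80000 nM for now.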

Compound 3, half-maximal inhibitory concentration: 27800 nM
The estimate for compound 3 lay 1.3-fold (0.10 log units) above the measured number; the measured number falls inside the stated range.
By their numbers in this assay, from the lowest: compounds 1, 3 and 2 (each within the scatter of the next).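

In this assay, ethyl to isopropyl gives a 1.1-fold lower number from compound 2 to compound 3 (0.05 log units; within the scatter), so branching on this saturated chain carbon does not separate compound 3 from compound 2. Isopropyl in place of methyl on the double-bonded chain carbon gives a 1.7-fold higher number from compound 1 to compound 3 (0.23 log units; within the scatter), which extends the same result to the largest change in this set: methyl, ethyl and isopropyl cannot be told apart here. No supporting measurement accompanies these results to explain them. Going by these compounds, whether a dimethylamino group or a longer chain in place of isopropyl would move the number beyond the scatter remains open.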